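The source may report more compounds than this note shows. Statements on the series, on what has been measured and on what is new or still open speak of the compounds shown alone.

Compound 1, `CC(C)=C(C)C#Cc1ccc(CCC(=O)O)cc1`: 105%
Compound 2, `C/C=C\C#Cc1ccc(CCC(=O)O)c(F)c1`: 91%
Compound 3, `O=C(O)CCc1ccc(C#CC2=CCCCC2)cc1`: 100%

All three were tested in a functional assay on 1321-N1 cells for agonist activity at Free fatty acid receptor 1 (Homo sapiens), read by calcium flux, with a stated time of 0.4 s (on this read-out higher numbers stand for larger maximal responses and lower numbers for smaller maximal responses), a measure of how large a response each compound can drive in these cells. Compound 2 gives the lowest of the three numbers: compound 3 sits close to it, within the usual scatter of such measurements, while compound 1 sits farther off, beyond the scatter.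

Compound 4, `C=C(C)C#Cc1ccc(CCC(=O)O)c(F)c1`, has not yet been measured. It differs from compound 2 in one place.
1-methylethenyl in place of prop-1-en-1-yl on a triple-bonded carbon
Among the compounds with values here, the one measured step that bears on this change, a swap of one group carrying a double bond for another on the triple-bonded carbon, is a number 5 percentage points lower from compound 1 to compound 3 (within the scatter), and it stayed within the scatter. Compound 2 and compound 4 hold the same atoms joined differently, so the expected step of a number 1 percentage points higher from compound 2 to compound 4 (within the scatter) should likewise not go beyond the scatter. Compound 4 is therefore estimated to give 92% in this assay, with a range from 80% to 105%.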

Compound 4, largest response reached (reported as efficacy), in percent of the reference or control that the assay uses: 106%
Estimate against measurement, compound 4: 14 percentage points below, outside the stated range (above it).
By their numbers in this assay, from the lowest: compounds 2, 3, 1 and 4 (each within the scatter of the next, the first and the last beyond it).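

On the triple-bonded carbon, 1-methylethenyl in place of prop-1-en-1-yl leaves the counts of heavy atoms and double bonds unchanged, yet in this assay the change gives a number 15 percentage points higher from compound 2 to compound 4 (beyond the scatter). Within the data shown here, the earlier swap of one double-bond group for another at this place, a number 5 percentage points lower from compound 1 to compound 3 (within the scatter), did not go beyond the scatter, so this step is the first sign here that how the same atoms are joined at this position can change the maximal response. Nothing measured here accounts for this step.

The compounds shown leave open whether the same swap gives a similar step on a core without the fluorine that compound 2 and compound 4 carry. They also leave open how a group with no double bond, such as propyl or cyclopropyl, would behave on the triple-bonded carbon.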